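From Phenoxy to Hydroxy: Cytotoxicity Expected to Stay Beyond Reach

The source may hold more compounds than are shown below. What is called first, only, known or untested is meant among the compounds shown, and "the series" means these compounds.

Measured compounds:
Compound 1, `CCOC(=O)c1c(-c2cccc(OC)c2)[nH]c2cc(OC)ccc2c1=O`, gives only a limit, > 21500 nM, in an ADME assay on Raji cells (Homo sapiens) for cytotoxicity, read by luminescence, with a stated time of 72 h; on this read-out higher numbers stand for an effect only at larger amounts of compound and lower numbers for an effect already at smaller amounts.
Compound 2, `CCOC(=O)c1c(-c2cccc(OC(C)C)c2)[nH]c2cc(OC)ccc2c1=O`, gives only a limit, > 21500 nM, in this assay.
Compound 3, `CCOC(=O)c1c(-c2cccc(Oc3ccccc3)c2)[nH]c2cc(OC)ccc2c1=O`, gives only a limit, > 21500 nM, in this assay.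

On the numbers shown, compound 3 stands at a limit rather than at a number, and so do the other two values: the limit of > 21500 nM in this assay, at which 3 of the 3 values shown sit. Compound 4, `CCOC(=O)c1c(-c2cccc(O)c2)[nH]c2cc(OC)ccc2c1=O`, differs from compound 3 in a single place: hydrogen in place of phenyl on an oxygen on an aromatic ring. Within the data shown here, three measured steps touch the same oxygen: a step that the two limits leave unreadable from compound 1 to compound 2, a step that the two limits leave unreadable from compound 1 to compound 3 and a step that the two limits leave unreadable from compound 2 to compound 3. Each of them runs between two limits, so no size can be read from any of them. Among the measured compounds shown here, no measured step therefore gives a readable size for the step to compound 4 in this assay. The only ground is that every compound with a different group on this oxygen stayed at the limit. Compound 4 is expected to stay there too, which means an expected step that the limit leaves unreadable from compound 3 to compound 4. The estimate for compound 4 is 30000 nM, with a range from 10000 nM to 100000 nM, most likely reported again only as a limit.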

Compound 4, half-maximal effective concentration: > 21500 nM
Compound 4 gave a limit, no number (the forecaster's own chance of this, stated with the estimate: 80%); the middle value does not contradict the limit.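

Compound 4 also gives only a limit, so its steps from compound 1, compound 2 and compound 3 cannot be read, and all four compounds end at the same place: the limit of > 21500 nM in this assay, at which 4 of the 4 values shown sit.

The compounds shown leave open what amount of each one would produce the effect in this assay, and whether changing the group on this oxygen alters that amount at all.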